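The compounds below may be only part of what the source reports. "The series", "measured", "known", "first", "only" and "open" are said of these compounds alone.

Measured compounds:

Compound 1 `CN(C)CCN1CCN(CC(=O)Nc2ccc(-c3nc4cc(Cl)ccc4o3)cc2)CC1` — 7100 nM
Compound 2 `CN(C)CCN1CCN(CC(=O)Nc2ccc(-c3nc4ccccc4o3)cc2)CC1` — 18700 nM
Compound 3 `Cc1cc(-c2nc3cc(Cl)ccc3o2)ccc1NC(=O)CN1CCN(CCCN(C)C)CC1` — 10500 nM

The set rests on three measured compounds in a functional assay on A549 cells (Homo sapiens) for cytotoxicity, read by MTT assay, with a stated time of 24 h; a lower number here means a stronger inhibitor, a higher number a weaker inhibitor. In this assay compound 1 gives 7100 nM, and compound 2 gives 18700 nM. Compound 2 differs from compound 1 by a single change, (hydrogen in place of chloro on an aromatic carbon), and that change produced a 2.6-fold higher number from compound 1 to compound 2 (0.42 log units; beyond the scatter), a step beyond the usual scatter. Compound 3, which in this assay gives 10500 nM, carries a core that differs from the core of compound 1 in more than one place; that difference is not broken down here. The values of compound 3 and compound 1 lie within the scatter of each other, as do those of compound 3 and compound 2, so nothing can be said about their order.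

Compound 4 `Cc1cc(-c2nc3ccccc3o2)ccc1NC(=O)CN1CCN(CCCN(C)C)CC1` is not yet measured. It differs from compound 3 by hydrogen in place of chloro on an aromatic carbon, the same change that separates compound 1 from compound 2: both times a chloro leaves and a hydrogen enters, on an aromatic carbon of a six-membered carbon-only ring within a fused system of two rings, meta and para to the fused ring. The expected step is a 2.6-fold higher number from compound 3 to compound 4 (0.41 log units; beyond the scatter), resting on the earlier 2.6-fold higher number from compound 1 to compound 2 (0.42 log units; beyond the scatter). Compound 4 is therefore expected to give about 27000 nM in this assay, with a plausible span from 12000 nM to 60000 nM.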

Compound 4, half-maximal inhibitory concentration: 22100 nM
Compound 4: middle estimate off by 1.2-fold (0.09 log units), on the high side; low and high end bracket the measured number.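

In this assay, hydrogen in place of chloro on an aromatic carbon again moved the number in the same direction, giving a 2.1-fold higher number from compound 3 to compound 4 (0.32 log units; beyond the scatter). Set beside the earlier step on the core of compound 1, the two steps agree in direction, and the gap in their size stays within what repeated measurements would allow: the same change on two cores in this assay, a 2.6-fold higher number (0.42 log units; beyond the scatter) from compound 1 to compound 2 and a 2.1-fold higher number (0.32 log units; beyond the scatter) from compound 3 to compound 4, 1.3-fold (0.10 log units) apart, within the scatter of two such steps This shows that, on these two cores, the step from 5-chloro-1,3-benzoxazol-2-yl to 1,3-benzoxazol-2-yl carried over from one core to the other, but with only two pairs it does not show that the step would hold on any further core in the series, and it says nothing about why the chloro has this effect.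

The compounds shown leave open what other groups would do at this place, such as fluoro, bromo, methoxy or a nitrile, since chloro and hydrogen are the only two compared here. They also leave open how much each separate difference between the two cores contributes, since those cores differ in more than one place and no pair shown takes those differences one at a time.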